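Nitro substitution on a fused aryl: notes on compound 4

The source may report more compounds than this note shows. Statements on the series, on what has been measured and on what is new or still open speak of the compounds shown alone.

Measured so far:
compound 1 `CCn1cc(-c2nc3ccccc3[nH]2)c(=O)c2cc(F)c(N3CCNCC3)cc21` gives 27400 nM
compound 2 `CCn1cc(-c2nc3ccccc3o2)c(=O)c2cc(F)c(N3CCNC(C)C3)c(F)c21` gives 5700 nM
compound 3 `CCn1cc(-c2nc3ccc([N+](=O)[O-])cc3[nH]2)c(=O)c2cc(F)c(N3CCNCC3)cc21` gives 2100 nM

All three were read in a functional assay on Bel-7402 cells (Homo sapiens) for cytotoxicity, read by MTT assay, with a stated time of 48 h; a higher number here means a weaker inhibitor, a lower number a stronger inhibitor. Compound 1 and compound 3 share a core; the step nitro in place of hydrogen on an aromatic carbon produced a 13-fold lower number from compound 1 to compound 3 (1.12 log units; beyond the scatter). Compound 2 sits on a different core, and the difference between the two cores is not broken down here. Its value stands between those of compound 1 and compound 3.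

Compound 4 `CCn1cc(-c2nc3ccc([N+](=O)[O-])cc3o2)c(=O)c2cc(F)c(N3CCNC(C)C3)c(F)c21` is not yet measured. It differs from compound 2 by nitro in place of hydrogen on an aromatic carbon, the same change as from compound 1 to compound 3, at the same place. On that single precedent, an expected step of an 8.1-fold lower number from compound 2 to compound 4 (0.91 log units; beyond the scatter) is estimated, somewhat smaller than the measured step because a 13-fold lower number from compound 1 to compound 3 (1.12 log units; beyond the scatter) rests on one pair on another core. Compound 4 is therefore expected near 700 nM, estimated between 250 nM and 2500 nM.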

Compound 4, half-maximal inhibitory concentration: 200 nM
Compound 4: the middle estimate sits 3.5-fold (0.54 log units) above what was measured; measured number outside the range, below it.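

In this assay, nitro in place of hydrogen on an aromatic carbon again lowers the number, with a 29-fold lower number from compound 2 to compound 4 (1.45 log units; beyond the scatter). The change carries over to the core of compound 2 with a step of matching size: the same change on two cores in this assay, a 13-fold lower number (1.12 log units; beyond the scatter) from compound 1 to compound 3 and a 29-fold lower number (1.45 log units; beyond the scatter) from compound 2 to compound 4, 2.2-fold (0.34 log units) apart, within the scatter of two such steps. Among these compounds, this rests on only two pairs, with the nitro group in the same place on both cores, so it does not show why the step arises or whether it would hold on any other core.

The compounds shown leave open whether the step is particular to nitro or would also appear with an amine, a nitrile or a trifluoromethyl group at that place. They also leave open how nitro behaves on another carbon of the same aromatic ring.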